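The source may report more compounds than this note shows. Statements on the series, on what has been measured and on what is new or still open speak of the compounds shown alone.

Working notes on the series. Among the measured compounds shown here, in an ADME assay on BHK cells (Mesocricetus auratus) for cytotoxicity, read by MTT assay, with a stated time of 96 h (on this read-out lower numbers stand for higher toxicity in this test and higher numbers for lower toxicity in this test), compound 1 `FC(F)(F)c1cccc(NC(=S)Nc2ccc(Cl)cc2)c1` gives 10000 nM, and compound 2 `FC(F)(F)c1cccc(NC(=S)Nc2cccc(Br)c2)c1` gives 10000 nM, so compound 1 stands level with the only other measured member. Compound 3 `CCOC(=O)c1ccc(NC(=S)Nc2cccc(C(F)(F)F)c2)cc1` has not yet been measured. Its difference from compound 1 is ethoxycarbonyl in place of chloro on an aromatic carbon, para to a large group.

For the measured compounds named here, only one measured step bears on this change: no change at the digits printed from compound 1 to compound 2 (within the scatter), with 3-bromophenyl in place of 4-chlorophenyl on an amide-type nitrogen. Going by the values given here, that step is the sole evidence, and it involves a different replacement. Neither measured compound carries ethoxycarbonyl, so the data give no direct reading of this group and the range has to stay wide. With compound 2 at 10000 nM, no step beyond the scatter is expected for compound 3, and neither direction is favoured. The estimated step is no change at the digits printed from compound 1 to compound 3 (within the scatter). For compound 3 the expected value is 10000 nM, with an estimated range of 4000 nM to 30000 nM.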

Compound 3, half-maximal cytotoxic concentration: 50000 nM
For compound 3 the middle estimate is 5.0-fold (0.70 log units) below the measured one; the measured number lies above the stated range.
By their numbers in this assay, from the lowest: compounds 1 and 2 (each within the scatter of the next); then compound 3.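

In this assay, the position para to a large group turns out to respond to substitution: ethoxycarbonyl in place of chloro gives a 5.0-fold higher number from compound 1 to compound 3 (0.70 log units; beyond the scatter), which on this read-out points towards lower toxicity in this test. The only earlier step, 3-bromophenyl in place of 4-chlorophenyl, gave no change at the digits printed from compound 1 to compound 2 (within the scatter), so until now the series had shown no movement beyond the scatter, and a change on this aromatic carbon is the first to produce one. Nothing available accounts for the size or direction of this step.

A single replacement leaves open whether the step belongs to the ethoxycarbonyl group as a whole or to some part of it, and a carboxylic acid, a methyl ester or a primary amide in the same place would help separate these readings. From the compounds shown here alone, it also remains open whether a similar step would appear in compounds that carry a group other than trifluoromethyl on the shared core.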